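Cyclopropyl in place of 3-chlorophenyl on the shared core

A few compounds are considered here, and "the series" means these few. Any claim that something is new, unique, unknown or untested is made for them only; others in the source may bear on it.

Two compounds have been measured:
compound 1, `O=C(O)c1cccc(Cc2c(-c3ccccc3)nn3cc(Br)ccc23)n1`, 11 nM in a functional assay on cells for antagonist activity at prostaglandin E2 receptor EP1 subtype (Rattus norvegicus), read by fluorescence and calcium flux, with a stated time of 60 s; a higher number here means a weaker inhibitor, a lower number a stronger inhibitor
compound 2, `O=C(O)c1cccc(Cc2c(-c3cccc(Cl)c3)nn3cc(Cl)ccc23)n1`, 480 nM in this assay

In this assay compound 1 gives 11 nM, while compound 2 gives 480 nM, the higher of the two numbers, so compound 2 is the weaker inhibitor of the pair, and the gap between them lies beyond the scatter. The two compounds differ in more than one place, so what each single change contributes to that gap cannot be read from these numbers.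

Compound 3, `O=C(O)c1cccc(Cc2c(C3CC3)nn3cc(Cl)ccc23)n1`, has not yet been measured. It differs from compound 2 in one place: cyclopropyl in place of 3-chlorophenyl on an aromatic carbon. Going by the values given here, no measured pair shows the effect of this change on the shared core, so the expected step from compound 2 to compound 3 in this assay can only be sketched broadly.

Compound 3 is expected to land in roughly the same region as compound 2, with a step of a 1.4-fold lower number from compound 2 to compound 3 (0.14 log units; within the scatter) estimated and the direction uncertain. For compound 3 the estimate is 350 nM, with a range from 40 nM to 3000 nM.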

Compound 3, half-maximal inhibitory concentration: 1500 nM
The estimate for compound 3 lay 4.3-fold (0.63 log units) below the measured number; low and high end bracket the measured number.
By their numbers in this assay, from the lowest: compound 1; then compound 2; then compound 3.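

In this assay, going by these compounds alone, cyclopropyl in place of 3-chlorophenyl gives a 3.1-fold higher number from compound 2 to compound 3 (0.49 log units; beyond the scatter), the first change at a single place on the shared core whose effect can be read. The position, on an aromatic carbon of a five-membered aromatic ring with 2 nitrogen, therefore registers what it carries: exchanging the six-membered aromatic ring of carbon only and its chlorine for a three-membered non-aromatic ring weakens inhibition by a modest step that lies beyond the scatter, yet compound 3 keeps a measurable value in the same assay. The compounds shown offer no independent evidence on why this exchange raises the number.

Within the data shown here, what remains open is whether the loss follows the ring, the chlorine or the heavy-atom count, since no compound separates these, and how an unsubstituted phenyl, a methyl group, a longer alkyl chain or an amine would behave at this position on the chloro-bearing core. Compound 1 differs from compound 2 in more than one place, so the separate contributions of its unsubstituted phenyl and its bromine also cannot be read.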